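A thiophen-2-yl swap on a sulfonamide at the limit

The source may report more compounds than this note shows. Statements on the series, on what has been measured and on what is new or still open speak of the compounds shown alone.

Measured so far in a functional assay on HeLa cells (Homo sapiens) for antiproliferative activity, read by MTT assay, with a stated time of 48 h; a higher number here means a weaker inhibitor, a lower number a stronger inhibitor
Compound 1 `Cn1cc(-c2cnc3ccnc(N)c3c2)cn1` gives 40800 nM
Compound 2 `CCNc1nccc2ncc(-c3cnn(C)c3)cc12` gives > 50000 nM as a limit
Compound 3 `Cc1ccc(S(=O)(=O)Nc2nccc3ncc(-c4cnn(C)c4)cc23)cc1` gives > 50000 nM as a limit

In this assay compound 3 reads > 50000 nM and that is a limit, not a number. Compound 2 stands with it at the limit of > 50000 nM in this assay, at which 2 of the 3 values shown sit, and compound 1 alone gives a number.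

Compound 4 `Cn1cc(-c2cnc3ccnc(NS(=O)(=O)c4cccs4)c3c2)cn1` keeps the shared core and the sulfonamide nitrogen and alters one group, with thiophen-2-yl in place of 4-methylphenyl on a sulfonyl sulfur. Among the measured compounds shown here, no measured step touches this group. For the measured compounds named here, the one measured step (an at least 1.2-fold higher number from compound 1 to compound 2 (0.08 log units; that floor lies within the scatter)) puts ethyl in place of hydrogen on a nitrogen on an aromatic ring, which is a different change, and its floor lies within the scatter. It therefore gives no size to carry over.

The expected step (a number no higher from compound 3 to compound 4 (the limit leaves the size open)) in this assay is none beyond the scatter, with no direction favoured. That expectation rests on compound 3 and its limit > 50000 nM alone, so another reading at the limit is considered likely. For compound 4 the estimate is 50000 nM with an expected range from 20000 nM to 100000 nM in the same assay.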

Compound 4, half-maximal inhibitory concentration: 17400 nM
Beside the measured number, compound 4's estimate is 2.9-fold (0.46 log units) above it; the whole stated range lies above it.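

In this assay, the group carried on the sulfonyl sulfur proves to matter: thiophen-2-yl in place of 4-methylphenyl gives an at least 2.8-fold lower number from compound 3 to compound 4 (0.45 log units; beyond the scatter). The (thiophen-2-yl)sulfonyl group also separates from the simpler groups on the nitrogen on an aromatic ring, with an at least 2.8-fold lower number from compound 2 to compound 4 (0.45 log units; beyond the scatter) when it replaces ethyl and a 2.3-fold lower number from compound 1 to compound 4 (0.37 log units; beyond the scatter) when it replaces hydrogen, whereas the earlier step on that nitrogen had a floor within the scatter. The first two of these steps give only a floor and not a full size, because each starts from a limit: the limit of > 50000 nM in this assay, at which 2 of the 4 values shown sit.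

The compounds shown do not separate the effect of the five-membered ring from that of its sulfur, nor the loss of the methyl from the change of ring, and a plain phenyl or a furan-2-yl on the sulfonyl sulfur would bear on both questions. They also leave open whether the sulfonyl link itself is needed, which an amide carbonyl in its place would test while keeping thiophen-2-yl.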